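Methylamino Analogues of Two Dichlorinated Cores Against KB Cells

The source may report more compounds than this note shows. Statements on the series, on what has been measured and on what is new or still open speak of the compounds shown alone.

Compound 1 `Nc1nc2c(Cl)cc(Cl)cc2n1COCCO` was tested in a functional assay on KB cells (Homo sapiens) for inhibition; a lower number here means a stronger inhibitor, a higher number a weaker inhibitor. In this assay compound 1 gives only the limit > 100000 nM. Compound 2 `CNc1nc2c(Cl)cc(Cl)cc2n1COCCO` carries methyl in place of hydrogen on a nitrogen on an aromatic ring. In this assay compound 2 likewise gives only the limit > 100000 nM. Between them stands a step that the two limits leave unreadable from compound 1 to compound 2. Compound 3 `Nc1nc2c(Cl)c(Cl)ccc2n1COCCO` has the same atoms as compound 1 joined differently; the difference between the two cores is not broken down here. In this assay compound 3 also gives only the limit > 100000 nM. Compound 4 `CNc1nc2c(Cl)c(Cl)ccc2n1COCCO` has not yet been measured; it differs from compound 3 by methyl in place of hydrogen on a nitrogen on an aromatic ring, the same change as that from compound 1 to compound 2. Because the limit of > 100000 nM in this assay, at which 3 of the 3 values shown sit, holds every value seen so far, the step expected from compound 3 to compound 4 is a step that the limit leaves unreadable from compound 3 to compound 4, of no readable size. Compound 4 is therefore expected to give about 150000 nM, estimated between 50000 nM and 500000 nM.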

Compound 4, half-maximal inhibitory concentration: > 100000 nM
Compound 4 was reported as a limit (the forecaster's own chance of this, stated with the estimate: 90%); the middle value is on the limit's open side.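

No step can be read from compound 3 to compound 4 in this assay, and the values give only a limit: the limit of > 100000 nM in this assay, at which 4 of the 4 values shown sit.

The compounds shown leave open whether methylamino in place of amino changes inhibition on either core, and whether the two cores differ at all.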